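This account rests on a few compounds, and the source may have more. Where it says the series, first, only, none or still open, it means among the compounds named here.

Measured compounds:
- compound 1, `CC(C)(C)c1ccc(-c2ccn3c(CC(F)(F)F)cnc3c2C#N)cc1`, in a functional assay on CHO cells with metabotropic glutamate receptor 2 (Homo sapiens) as the target, read by GTPgammaS binding (on this read-out lower numbers stand for an effect already at smaller amounts and higher numbers for an effect only at larger amounts of compound), compound 1 gives 447 nM
- compound 2, `CCCc1cnc2c(C#N)c(N3CCN(c4nc(C)cc(C)n4)CC3)ccn12`, in this assay compound 2 gives 646 nM
- compound 3, `N#Cc1c(-c2ccc(N3CCCCC3)cc2)ccn2c(CC(F)(F)F)cnc12`, in this assay compound 3 gives 234 nM

Compound 3 stands at the low end of these three numbers. Its gap to compound 1 falls inside the usual scatter of repeated measurements, so the two cannot be ranked against each other, whereas compound 2 sits clearly above compound 3. Compound 4, `N#Cc1c(-c2ccc(Oc3ccccc3)cc2)ccn2c(CC(F)(F)F)cnc12`, shares the core of compound 3 and differs from it in one place: phenoxy in place of piperidin-1-yl on an aromatic carbon. Among the measured compounds shown here, only one measured step changes the same position: a 1.9-fold lower number from compound 1 to compound 3 (0.28 log units; within the scatter), a swap at that aromatic carbon that stayed inside the scatter. Nothing measured involves a phenoxy group, so the expectation rests on this single step alone. Since exchanging one group for another at that carbon did not move the number beyond the scatter, a similarly small step is expected for compound 4, with no clear direction. The estimated step from compound 3 is a 1.7-fold higher number from compound 3 to compound 4 (0.23 log units; within the scatter), which is expected to stay inside the scatter. The estimated value for compound 4 in this assay is 400 nM, with a likely range from 150 nM to 1100 nM.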

Compound 4, half-maximal effective concentration: 186 nM
For compound 4 the middle estimate is 2.2-fold (0.33 log units) above the measured one; measured number inside the range.
By their numbers in this assay, from the lowest: compounds 4, 3, 1 and 2 (each within the scatter of the next, the first and the last beyond it).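

At this aromatic carbon, para to a large group, exchanging piperidin-1-yl for phenoxy in this assay gives a 1.3-fold lower number from compound 3 to compound 4 (0.10 log units; within the scatter) and so leaves the reading unchanged within the scatter, even though a non-aromatic ring containing nitrogen gives way to an aromatic carbon ring attached through oxygen. Among the compounds shown here, the comparison with tert-butyl gives a 2.4-fold lower number from compound 1 to compound 4 (0.38 log units; beyond the scatter) as the first step at this position to pass the scatter, which shows that the group here can shift the number, though only modestly. Compound 3 lies within the scatter of both compound 1 and compound 4, so these three groups do not form three separate levels, and no other data are available to explain the differences.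

From the compounds shown here alone, it remains open whether a carboxylic acid, a primary amine, a methoxy group or a plain hydrogen at this carbon would keep the number in the same range. Also open, going by these compounds, is whether a phenoxy group carrying a fluorine atom or a methoxy group on its outer ring would lower the number further or raise it.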